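A Fluorine Swap Repeated on a Second Core

A few compounds are considered here, and "the series" means these few. Any claim that something is new, unique, unknown or untested is made for them only; others in the source may bear on it.

Compound 1 `CC(=O)c1cc(-c2ccccc2)cc2cc(-c3ccc(F)cc3)[nH]c12` and compound 2 `CC(=O)c1cc(-c2ccc(F)cc2)cc2cc(-c3ccc(F)cc3)[nH]c12` share one core and differ only by fluoro in place of hydrogen on an aromatic carbon. In a functional assay on HeLa cells (Homo sapiens) for cytotoxicity, read by MTT assay, with a stated time of 2 days, tested at 0.1 uM (a lower number here means a stronger effect, a higher number a weaker effect of the compound at the concentration tested), compound 1 gives 91.1%, and compound 2 gives 90.1%. The step of a number 1 percentage points lower from compound 1 to compound 2 (within the scatter), so adding this fluorine left the read-out essentially where it was.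

Compound 3 `CC(=O)c1cc(/C=C/c2ccccc2)cc2cc(-c3ccccc3)[nH]c12` is built on a different core; the difference between the core of compound 1 and the core of compound 3 is not broken down here. In this assay compound 3 gives 99.1%. Set against compound 1 and compound 2, all three values lie within the scatter of one another, so no order among them can be read.

Compound 4 `CC(=O)c1cc(/C=C/c2ccc(F)cc2)cc2cc(-c3ccccc3)[nH]c12` has not yet been measured. It differs from compound 3 by fluoro in place of hydrogen on an aromatic carbon. This is the same change already seen between compound 1 and compound 2, made at the same kind of place, only now on the core of compound 3.

Since the earlier step of a number 1 percentage points lower from compound 1 to compound 2 (within the scatter) stayed within the scatter, and since compound 3 gives 99.1%, the step from compound 3 to compound 4 is expected to be small, a number 3.1 percentage points lower from compound 3 to compound 4 (within the scatter). Compound 4 is therefore estimated to give about 96% in this assay, most likely between 87% and 104%.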

Compound 4, a percentage reported as activity, at one concentration (the size of the read-out at that concentration, not a potency): 74.2%
Compound 4: middle estimate off by 21.8 percentage points, on the high side; the measured number lies below the stated range.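

On the core of compound 3, fluoro in place of hydrogen gives a number 24.9 percentage points lower from compound 3 to compound 4 (beyond the scatter) in this assay, and since a lower number here means a stronger effect, the 2-(4-fluorophenyl)ethenyl compound acts more strongly on the cells than its 2-phenylethenyl partner at the concentration tested. The same small change therefore did not carry from one core to the other with the same size, so a step seen on one core was a poor guide to the step on the other: the same change on two cores in this assay, a number 1 percentage points lower (within the scatter) from compound 1 to compound 2 and a number 24.9 percentage points lower (beyond the scatter) from compound 3 to compound 4, 23.9 percentage points apart, beyond the scatter of two such steps. This does not show which feature of the two cores lies behind the gap, and two pairs of compounds, each tested at a single concentration, give no rule for what this fluorine would do on any further core.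

The compounds shown leave open whether fluoro is special or whether another group at the same place on the ring, such as chloro, methoxy or an amine, would give a step like the one to compound 4. They also leave open how compound 4 behaves at other concentrations, as its read-out gives the size of an effect at one concentration and not a potency.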